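The compounds below may be only part of what the source reports. "The series", "measured", "known", "first", "only" and "open" are said of these compounds alone.

Working notes on the series. Compound 1 `CCCCCc1ccc(-c2oc3nc(=O)n([C@H]4C[C@H](OC(C)=O)[C@@H](COC(C)=O)O4)cc3c2C#Cc2ccc(C)cc2)cc1` gives 100000 nM in an ADME assay on HEL cells (Homo sapiens) for cytotoxicity, read by cell counting, with a stated time of 3 days; a higher number here means that more compound is tolerated, a lower number that less compound is tolerated. Compound 2 `CCCCCc1ccc(C#Cc2c(-c3ccc(C)cc3)oc3nc(=O)n([C@H]4C[C@H](OC(C)=O)[C@@H](COC(C)=O)O4)cc23)cc1` gives 20000 nM in this assay. Compound 3 `CCCCCc1ccc(-c2oc3nc(=O)n([C@H]4C[C@H](OC(C)=O)[C@@H](COC(C)=O)O4)cc3c2C#CCCO)cc1` gives 100000 nM in this assay.

On these three numbers compound 3 stands level with compound 1, the two together giving the highest numbers of the set; compound 2 gives the lowest number, and its gap to compound 3 lies beyond the scatter. Among the measured compounds shown here, no step is drawn between compound 2 and compound 3, so only the two values themselves are noted.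

The next member is compound 4 `CCCCCc1ccc(-c2oc3nc(=O)n([C@H]4C[C@H](OC(C)=O)[C@@H](COC(C)=O)O4)cc3c2C#CCO)cc1`. Its difference from compound 3: hydroxy in place of hydroxymethyl on a saturated chain carbon bound to a triple-bonded carbon. For the measured compounds named here, the only measured step that touches this part of the structure is no change at the digits printed from compound 1 to compound 3 (within the scatter), a much larger exchange of groups at the same place that left the number where it was. A still smaller change, from 2-hydroxyethyl to hydroxymethyl, gives no ground to expect anything beyond the scatter, so the expected step is no change at the digits printed from compound 3 to compound 4 (within the scatter).

Compound 4 is therefore estimated at 100000 nM in this assay, with an expected range from 50000 nM to 200000 nM.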

Compound 4, minimum cytotoxic concentration: 100000 nM
Compound 4: the middle estimate sits on the measured number at the digits printed; the measured number falls inside the stated range.
By their numbers in this assay, from the lowest: compound 2; then compounds 1, 3 and 4 (each within the scatter of the next).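

In this assay, 2-hydroxyethyl giving way to hydroxymethyl on the saturated chain carbon bound to a triple-bonded carbon gives no change at the digits printed from compound 3 to compound 4 (within the scatter), so a change in the length of the hydroxy-bearing chain itself, and not only the exchange of a whole group, now leaves the number where it stood. Hydroxymethyl in place of 4-methylphenyl on a triple-bonded carbon gives no change at the digits printed from compound 1 to compound 4 (within the scatter), which joins no change at the digits printed from compound 1 to compound 3 (within the scatter) as a second exchange of the aromatic group for a hydroxy-bearing chain with the same outcome, so three different groups at this place now read alike on the shared core. Nothing among the available data bears on why the number holds across these groups.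

Going by these compounds, whether an amine or a carboxylic acid at this place, or a chain longer than 2-hydroxyethyl, would keep the number at this level remains open. What a plain propyl chain, with no hydroxy group on it, would give at the same place also remains open, so the compounds shown do not tell whether the hydroxy group has any part in the result.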